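Positional shift of the amino group in the series

The source may hold more compounds than are shown below. What is called first, only, known or untested is meant among the compounds shown, and "the series" means these compounds.

compound 1 `COc1cc(-c2noc(-c3ccccc3)n2)cc(OC)c1OC` — > 50000 nM
compound 2 `COc1cc(-c2noc(-c3ccc(N)cc3)n2)cc(OC)c1OC` — 1700 nM
compound 3 `COc1cc(-c2noc(-c3cccc(N)c3)n2)cc(OC)c1OC` — not yet measured

For the measured compounds named here, in a functional assay on cells (Splenocyte, Mus musculus, strain BALB/c) for inhibition, read by scintillation counting and thymidine incorporation, with stated times of 48 h and 8 h (on this read-out lower numbers stand for stronger inhibition and higher numbers for weaker inhibition), compound 2 gives 1700 nM, the only number reported. For compound 1 the value > 50000 nM is a limit of this assay rather than a number (the limit of > 50000 nM in this assay, at which 1 of the 2 values shown sits). Going by the values given here, the single measured step, an at least 29-fold lower number from compound 1 to compound 2 (1.46 log units; beyond the scatter), shows that adding an amino group to the phenyl ring turns an unmeasurable compound into an active one.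

Compound 3 differs from compound 2 by 3-aminophenyl in place of 4-aminophenyl on an aromatic carbon. Among the compounds with values here, no measured step speaks to moving the amino group around the ring; the step to compound 2 only shows that its presence matters. A moderate loss is therefore expected, with wide uncertainty, giving a 2.9-fold higher number from compound 2 to compound 3 (0.47 log units; beyond the scatter). Compound 3 is estimated at 5000 nM, within a range of 1000 nM to 30000 nM.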

Compound 3, half-maximal inhibitory concentration: 5500 nM
The estimate for compound 3 lay 1.1-fold (0.04 log units) below the measured number, within the range that was stated.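

Moving the amino group is not neutral in this assay: 3-aminophenyl in place of 4-aminophenyl gives a 3.2-fold higher number from compound 2 to compound 3 (0.51 log units; beyond the scatter), so the position on the phenyl ring matters, not only the presence of the group. The gain over the plain phenyl survives this shift, with an at least 9.0-fold lower number from compound 1 to compound 3 (0.95 log units; beyond the scatter), so both amino placements shown give lower numbers than no amino group. The true size of that step stays unknown, compound 1 being a limit and not a number: the limit of > 50000 nM in this assay, at which 1 of the 3 values shown sits.

From the compounds shown here alone, whether the amino group itself is required remains open, and a hydroxyl, a methylamino or an acetamido group in its place would address that. Also open, going by these compounds, is whether the preference for 4-aminophenyl over 3-aminophenyl holds when other parts of the shared core change.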